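Working notes: chloro to trifluoromethyl on the shared core

A few compounds are considered here, and "the series" means these few. Any claim that something is new, unique, unknown or untested is made for them only; others in the source may bear on it.

Measured so far:
compound 1 `O=C(Nc1cccc(C(F)(F)F)c1)c1cc(=O)[nH]c2cc(Br)ccc12`: > 20000 nM
compound 2 `O=C(Nc1cccc(Cl)c1)c1cc(=O)[nH]c2cc(Br)ccc12`: > 20000 nM
compound 3 `O=C(Nc1cc(F)cc(F)c1)c1cc(=O)[nH]c2cc(Cl)ccc12`: 9000 nM

In a functional assay on KYSE-70 cells for antiproliferative activity against KYSE-70 cell line (Homo sapiens), read by MTT assay, with a stated time of 72 h (on this read-out higher numbers stand for weaker inhibition and lower numbers for stronger inhibition), compound 1 returns only a limit, > 20000 nM. Compound 2 likewise returns only a limit, > 20000 nM. The change from compound 2 to compound 1 is trifluoromethyl in place of chloro on an aromatic carbon, and its step is a step that the two limits leave unreadable from compound 2 to compound 1 because both sit at the limit of > 20000 nM in this assay, at which 2 of the 3 values shown sit. Among the compounds with values here, compound 3 gives the one number in the set, 9000 nM in this assay. The difference between the cores of compound 2 and compound 3 is not broken down here.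

Compound 4 `O=C(Nc1cc(F)cc(F)c1)c1cc(=O)[nH]c2cc(C(F)(F)F)ccc12` is not yet measured. From compound 3 it differs by trifluoromethyl in place of chloro on an aromatic carbon. This is the same kind of change as from compound 2 to compound 1, not the same: there the place was on an aromatic carbon of a six-membered aromatic ring of carbon only, meta to a large group; here the ring is part of a fused or bridged system of two rings, meta to a fused ring and para to a fused ring. The earlier step has no readable size, so the expectation rests on compound 3 alone. Against compound 3, 9000 nM in this assay, the expected step is a 1.3-fold higher number from compound 3 to compound 4 (0.12 log units; within the scatter). Compound 4 is thus estimated at 12000 nM, expected between 4000 nM and 30000 nM.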

Compound 4, half-maximal inhibitory concentration: 14200 nM
Estimate against measurement, compound 4: 1.2-fold (0.07 log units) below; low and high end bracket the measured number.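

In this assay, trifluoromethyl in place of chloro on an aromatic carbon of the fused system gives a 1.6-fold higher number from compound 3 to compound 4 (0.20 log units; within the scatter), so compound 3 and compound 4 cannot be told apart on this core. The same kind of change on the other core, at a different place, cannot be read, because both of its compounds return only a limit: the limit of > 20000 nM in this assay, at which 2 of the 4 values shown sit. With a single readable step, the notes show that the swap was tolerated on one core and place, but not whether this carries over to another core.

The substituents shown on the aromatic rings are limited to fluoro, chloro, bromo and trifluoromethyl, so the response in this assay to an amine, a carboxylic acid or a methoxy group at these places remains open. Also open, from the compounds shown here alone, is whether any replacement at the place changed here can move the read-out beyond the scatter from compound 3.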